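This account rests on a few compounds, and the source may have more. Where it says the series, first, only, none or still open, it means among the compounds named here.

Measured so far:
compound 1 `COc1ccccc1C(=O)NCCNc1cccc(NS(=O)(=O)c2cc(-c3cccc(C(=O)N(C)C)c3)ccc2OC)c1` — 50 nM
compound 2 `COc1ccccc1C(=O)NCCNc1cccc(NS(=O)(=O)c2cc(-c3cccc(N)c3)ccc2OC)c1` — > 1000 nM (a limit, not a number)

In an assay on CHO-K1 cells for agonist activity at Orexin receptor type 2 (Homo sapiens), read by a luciferase reporter (on this read-out lower numbers stand for an effect already at smaller amounts and higher numbers for an effect only at larger amounts of compound), compound 1 gives 50 nM. Compound 2 sits at the limit of > 1000 nM in this assay, at which 1 of the 2 values shown sits, so its place on the numbers is only bounded from one side. Within the data shown here, the one measured step, an at least 20-fold higher number from compound 1 to compound 2 (1.30 log units; beyond the scatter), shows that amino in place of dimethylcarbamoyl costs much. Compound 3 `COc1ccccc1C(=O)NCCNc1cccc(NS(=O)(=O)c2cc(-c3cccnc3)ccc2OC)c1` carries pyridin-3-yl in place of 3-aminophenyl on an aromatic carbon. Among the measured compounds shown here, no measured step covers this change; the step from compound 1 to compound 2 concerns a different group and offers no direct guide. Compound 3 is expected at 500 nM, range 100 nM to 3000 nM, with the expected step of an at least 2.0-fold lower number from compound 2 to compound 3 (0.30 log units; that floor lies within the scatter).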

Compound 3, half-maximal effective concentration: 268 nM
Estimate against measurement, compound 3: 1.9-fold (0.27 log units) above; measured number inside the range.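

Pyridin-3-yl on this aromatic carbon keeps a measurable effect without any dimethylcarbamoyl group, with an at least 3.7-fold lower number from compound 2 to compound 3 (0.57 log units; beyond the scatter). That step is bounded from one side only, because compound 2 stands at a limit of the assay: the limit of > 1000 nM in this assay, at which 1 of the 3 values shown sits.
Pyridin-3-yl still falls short of 3-(dimethylcarbamoyl)phenyl, with a 5.4-fold higher number from compound 1 to compound 3 (0.73 log units; beyond the scatter).

Open, going by these compounds, is how a primary amide, a carboxylic acid or a pyridin-4-yl ring would compare at this carbon. Also open, on these data alone, is whether a dimethylcarbamoyl group on the pyridin-3-yl ring would close the gap to compound 1.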